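The source may hold more compounds than are shown below. What is called first, only, known or untested is meant among the compounds shown, and "the series" means these compounds.

Measured compounds:
compound 1, `Cc1cc(NC(=O)c2cc([N+](=O)[O-])ccc2Cl)cc(-c2nc3ccccc3s2)c1O`, 430 nM
compound 2, `O=C(Nc1nc(-c2cccc(F)c2)cs1)c1cc([N+](=O)[O-])ccc1Cl`, 780 nM
compound 3, `COc1cc(Cl)c(C(=O)Nc2cccc(-c3nc4ccccc4s3)c2)cc1[N+](=O)[O-]`, 10 nM

Of the compounds shown here, three have been measured in a physicochemical assay for solubility, read by spectrophotometry, in phosphate buffer, measured as kinetic solubility, with a stated time of 18 h, at pH 7.4; a higher number here means a more soluble compound, a lower number a less soluble compound. Compound 3 stands lowest of the three: the nearest number is that of compound 1, which lies beyond the scatter of the method, and compound 2 lies further away still, also beyond the scatter. All three share the nitro-bearing chlorinated benzamide, and no two of them differ in a single place, so no measured step can be read off between any pair.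

Compound 4, `O=C(Nc1cccc(-c2nc3ccccc3s2)c1)c1cc([N+](=O)[O-])c(O)cc1Cl`, has not yet been measured in this assay. It differs from compound 3 in one place: hydrogen in place of methyl on an oxygen on an aromatic ring. Among the measured compounds shown here, no measured pair shows what this kind of change does in this assay, so the expectation rests on compound 3 alone and on the size of the change, which is small in heavy-atom terms. Compound 4 is expected to move upward from compound 3 by a 3.0-fold higher number from compound 3 to compound 4 (0.48 log units; beyond the scatter), a step that may or may not exceed the scatter. The estimate for compound 4 is 30 nM, with a range from 6 nM to 200 nM.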

Compound 4, solubility: 2200 nM
Compound 4: middle estimate off by 73-fold (1.87 log units), on the low side; the measured number lies above the stated range.
By their numbers in this assay, from the lowest: compound 3; then compounds 1 and 2 (each within the scatter of the next); then compound 4.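

In this assay, among the compounds shown here, compounds 3 and 4 form the first pair that differs in one place, and hydrogen in place of methyl on an oxygen on an aromatic ring comes with a 220-fold higher number from compound 3 to compound 4 (2.34 log units; beyond the scatter), a large step. The earlier compounds shown here held no such pair, so nothing could be said about this position; it is now clear that the number is far from indifferent to what sits on this oxygen, even though the change from methoxy to hydroxy removes only one carbon and involves no ring and no net charge. Nothing at hand accounts for the size of this step, and it rests on this single pair.

As far as these compounds go, it remains open whether a step of this size would be seen with other groups in the same place, such as ethoxy, an amine or a carboxylic acid. It is also unknown whether the same change from methoxy to hydroxy would give a similar step on a different core, or at another oxygen on an aromatic ring.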